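This account rests on a few compounds, and the source may have more. Where it says the series, first, only, none or still open, it means among the compounds named here.

Values in a functional assay on MGC-803 cells (Homo sapiens) for inhibition, read by MTT assay, with a stated time of 72 h; a higher number here means a weaker inhibitor, a lower number a stronger inhibitor:
- Compound 1 `Cc1cc(Nc2cc(-c3ccccc3)[nH]n2)n2nc(SCc3ccccc3Br)nc2n1`: 3650 nM
- Compound 2 `Cc1cc(Nc2cc(-c3ccccc3)[nH]n2)n2nc(SCc3ccc(Cl)cc3)nc2n1`: 3950 nM
- Compound 3 `COc1ccc(CSc2nc3nc(C)cc(Nc4cc(-c5ccccc5)[nH]n4)n3n2)cc1`: 3170 nM

The three values are flat: a 1.2-fold lower number from compound 1 to compound 3 (0.06 log units; within the scatter), a 1.2-fold lower number from compound 2 to compound 3 (0.10 log units; within the scatter) and a 1.1-fold higher number from compound 1 to compound 2 (0.03 log units; within the scatter), all within the scatter. Compound 3 therefore has no real separation from the other two.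

Compound 4 `Cc1cc(Nc2cc(-c3ccccc3)[nH]n2)n2ncnc2n1` removes the whole side group: hydrogen in place of (4-methoxybenzyl)sulfanyl on an aromatic carbon. The measured steps bear on this only indirectly. Within the data shown here, each exchanges the substituted phenyl ring and keeps the sulfanyl link, and no measured compound lacks the side group, so no step sizes this change. The small size of a 1.2-fold lower number from compound 2 to compound 3 (0.10 log units; within the scatter) shows tolerance of a swap, not of a loss. A weaker result beyond the scatter is nevertheless expected in this assay, with wide uncertainty. The expected step is a 3.2-fold higher number from compound 3 to compound 4 (0.50 log units; beyond the scatter). Compound 4 is estimated at 10000 nM, with an expected range of 3000 nM to 40000 nM.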

Compound 4, half-maximal inhibitory concentration: 21700 nM
Estimate against measurement, compound 4: 2.2-fold (0.34 log units) below; measured number inside the range.
By their numbers in this assay, from the lowest: compounds 3, 1 and 2 (each within the scatter of the next); then compound 4.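

Among these compounds, at the aromatic carbon between two ring nitrogen atoms, the earlier swaps showed only that three substituted benzyl groups give values within the scatter of one another, whereas full loss of the side group has a measurable cost in this assay. Hydrogen in place of the group gives a weaker inhibitor than each of the three parents (a 6.8-fold higher number from compound 3 to compound 4 (0.84 log units; beyond the scatter); a 5.5-fold higher number from compound 2 to compound 4 (0.74 log units; beyond the scatter); a 5.9-fold higher number from compound 1 to compound 4 (0.77 log units; beyond the scatter)). All three steps lie beyond the scatter, so this position is not indifferent to the change. No available evidence accounts for this loss.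

Which part of the (4-methoxybenzyl)sulfanyl group carries the difference remains open, as the group here is either present whole or absent. A methylsulfanyl group, or an amine in place of the sulfur link, would separate the contribution of the aromatic ring from that of the link.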